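Hydroxyethyl in Place of Cyclopropyl on a Weakly Antiproliferative Series

The source may report more compounds than this note shows. Statements on the series, on what has been measured and on what is new or still open speak of the compounds shown alone.

compound 1 `O=C1O[C@H]([C@@H](O)Cn2cc(-c3cc(C(F)(F)F)cc(C(F)(F)F)c3)nn2)C(OCc2ccccc2)=C1OCc1ccccc1`: 35500 nM
compound 2 `CCCCCc1ccc(-c2cn(C/C=C3\OC(=O)C(OCc4ccccc4)=C3OCc3ccccc3)nn2)cc1`: > 100000 nM (a limit)
compound 3 `O=C1O[C@H]([C@@H](O)Cn2cc(C3CC3)nn2)C(OCc2ccccc2)=C1OCc1ccccc1`: 26500 nM

In a functional assay on HeLa cells (Homo sapiens) for antiproliferative activity, read by MTT assay, with a stated time of 72 h (on this read-out higher numbers stand for weaker inhibition and lower numbers for stronger inhibition), compound 1 gives 35500 nM. Compound 2 reaches only a limit of this assay, > 100000 nM, as noted in the limit of > 100000 nM in this assay, at which 1 of the 3 values shown sits. Compound 3 gives 26500 nM, the lowest of the two numbers; its gap to compound 1 lies within the scatter, so neither is called the stronger. Compound 4 `O=C1O[C@H]([C@@H](O)Cn2cc(CCO)nn2)C(OCc2ccccc2)=C1OCc1ccccc1` is not yet measured; it differs from compound 3 by 2-hydroxyethyl in place of cyclopropyl on an aromatic carbon. Within the data shown here, no measured pair shows this change, so a step within the scatter, or at most a modest shift toward weaker inhibition, is expected in this assay. Compound 4 is expected to give 32000 nM, with a range from 12000 nM to 85000 nM. That expectation amounts to a step of a 1.2-fold higher number from compound 3 to compound 4 (0.08 log units; within the scatter).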

Compound 4, half-maximal inhibitory concentration: 68800 nM
The estimate for compound 4 lay 2.2-fold (0.33 log units) below the measured number, within the range that was stated.
By their numbers in this assay, from the lowest: compounds 3, 1 and 4 (each within the scatter of the next, the first and the last beyond it). At a limit, above all of these: compound 2.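

Placing 2-hydroxyethyl instead of cyclopropyl on this aromatic carbon gives the first readable step in the series: in this assay, there is a 2.6-fold higher number from compound 3 to compound 4 (0.41 log units; beyond the scatter), a modest move toward weaker inhibition. The position therefore responds to its substituent, even when both groups have the same count of heavy atoms. No measured property shown here accounts for the step.

As far as these compounds go, it stays open whether the hydroxyl or the loss of the ring drives this shift; a plain ethyl group would separate the two. From the compounds shown here alone, how an aminoethyl group or a longer alkyl chain would behave at this carbon also remains open.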